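Replacing Acetamido with Fluoro on Compound 2

The compounds below may be only part of what the source reports. "The series", "measured", "known", "first", "only" and "open" are said of these compounds alone.

In an ADME assay on HEp-2 cells (Homo sapiens) for cytotoxicity (a higher number here means that more compound is tolerated, a lower number that less compound is tolerated), compound 1 (`CC(C)CCn1c(Cn2c(=O)n(C(C)C)c3ccccc32)nc2c(CN)cccc21`) gives 7000 nM and compound 3 (`CC(C)CCn1c(Cn2c(=O)n(CC(=O)OC(C)(C)C)c3ccccc32)nc2cc(C(=N)N)ccc21`) gives 7900 nM. Compound 2 (`CC(=O)NCc1ccc2c(c1)nc(Cn1c(=O)n(C(C)C)c3ccccc31)n2CCC(C)C`) stands highest of the three at 178000 nM, beyond the scatter from both others. Compound 4 (`CC(C)CCn1c(Cn2c(=O)n(C(C)C)c3ccccc32)nc2cc(CF)ccc21`) departs from it in one place: fluoro in place of acetamido on a saturated chain carbon bound to an aromatic carbon. This puts fluoro in place of acetamido on a saturated chain carbon bound to an aromatic carbon. For the measured compounds named here, no measured pair isolates this change, so the expectation is loose. With compound 2 at 178000 nM, far from the other two, a moderate fall beyond the scatter is expected. The estimated step is a 3.0-fold lower number from compound 2 to compound 4 (0.47 log units; beyond the scatter). For compound 4 the expected value is 60000 nM, within an estimated range of 15000 nM to 200000 nM.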

Compound 4, half-maximal cytotoxic concentration: 37300 nM
Compound 4: middle estimate off by 1.6-fold (0.21 log units), on the high side, and the stated range covers the measured number.
By their numbers in this assay, from the lowest: compounds 1 and 3 (each within the scatter of the next); then compound 4; then compound 2.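

For the compounds shown here, replacing acetamido with fluoro on a saturated chain carbon bound to an aromatic carbon provides the first one-place comparison in this assay, with a 4.8-fold lower number from compound 2 to compound 4 (0.68 log units; beyond the scatter). The group at this place therefore does bear on the number, although the step is modest. Nothing measured here accounts for the step.

The compounds shown leave open whether the lower number follows the loss of acetamido or the arrival of fluoro. A hydroxyl or a plain hydrogen on this carbon would help separate the two.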